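Dichlorophenyl urea of compound 1: expected strong inhibition

This account rests on a few compounds, and the source may have more. Where it says the series, first, only, none or still open, it means among the compounds named here.

Compound 1 `COc1cc2cc(Oc3ccc(NC(=O)Nc4ccc(C)cc4)cc3)c(C)nc2cc1OC` shows the highest number of the three measured ureas: in a functional assay on CCRF-CEM cells (Homo sapiens) for inhibition, read by sulforhodamine B assay, with a stated time of 48 h, tested at 10 uM (on this read-out higher numbers stand for a weaker effect at the one concentration tested and lower numbers for a stronger effect), compound 1 gives 101%. Compound 2 `COc1cc2cc(Oc3ccc(NC(=O)Nc4ccc(C(F)(F)F)cc4)cc3)c(C)nc2cc1OC` gives 68.5%, and compound 3 `COc1cc2cc(Oc3ccc(NC(=O)Nc4ccc(Cl)c(C(F)(F)F)c4)cc3)c(C)nc2cc1OC` gives -17.6%. The change from compound 1 to compound 4 `COc1cc2cc(Oc3ccc(NC(=O)Nc4ccc(Cl)c(Cl)c4)cc3)c(C)nc2cc1OC` is 3,4-dichlorophenyl in place of 4-methylphenyl on an amide-type nitrogen. Within the data shown here, two measured steps bear on it, both starting from compound 1: the step of a number 32.5 percentage points lower from compound 1 to compound 2 (beyond the scatter) and the step of a number 118.6 percentage points lower from compound 1 to compound 3 (beyond the scatter), the second of which is the closer model, since compound 3 also carries a chlorine on the ring that enters. The step of a number 86.1 percentage points lower from compound 2 to compound 3 (beyond the scatter) points the same way. Compound 4 is therefore expected to move far below compound 1, by about a number 96 percentage points lower from compound 1 to compound 4 (beyond the scatter). The estimate for compound 4 in this assay is 5%, with a range from -30% to 55%, which is expected to lie near compound 3 rather than compound 2.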

Compound 4, a percentage reported as activity, at one concentration (the size of the read-out at that concentration, not a potency): 13.3%
Compound 4: the middle estimate sits 8.3 percentage points below what was measured, within the range that was stated.
By their numbers in this assay, from the lowest: compound 3; then compound 4; then compound 2; then compound 1.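

The step of a number 87.7 percentage points lower from compound 1 to compound 4 (beyond the scatter) shows that a strong effect in this assay at this amide-type nitrogen does not depend on trifluoromethyl, since 3,4-dichlorophenyl also gives one. Trifluoromethyl still makes a difference, as chloro in its place gives a number 30.9 percentage points higher from compound 3 to compound 4 (beyond the scatter), and yet the two-chlorine ring clearly outdoes the singly substituted ring, with a number 55.2 percentage points lower from compound 2 to compound 4 (beyond the scatter). Nothing at hand accounts for these differences.

The compounds shown leave open whether a ring carrying a nitrile, a methoxy group or an amine would fall with the halogen-bearing rings or stay near compound 1. Since each number comes from one concentration, they also leave open how far these ureas differ in potency.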